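From carbamoyl to sulfonyl on a shared core

The compounds below may be only part of what the source reports. "The series", "measured", "known", "first", "only" and "open" are said of these compounds alone.

For the measured compounds named here, in a functional assay on DU-145 cells (Homo sapiens) for inhibition, read by trypan blue exclusion, with a stated time of 72 h (a lower number here means a stronger inhibitor, a higher number a weaker inhibitor), compound 1 (`Cn1c(=O)c(C(=O)Nc2ccc(F)cc2F)cc2cnc(Nc3ccc4[nH]ccc4c3)nc21`) gives 5000 nM and holds the highest of the three numbers so far, with a gap beyond the scatter to each of the other two. In this assay compound 2 (`CCCn1c(=O)c(S(=O)(=O)c2ccc(F)cc2F)cc2cnc(Nc3ccc4[nH]ccc4c3)nc21`) gives 1000 nM and compound 3 (`Cn1c(=O)c(S(=O)(=O)c2ccccc2)cc2cnc(Nc3cnc4[nH]ccc4c3)nc21`) gives 1000 nM as well. Both carry a sulfonyl group, but each also differs from compound 1 elsewhere, so no single change has yet been measured on its own.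

Compound 4 (`COc1ccc(S(=O)(=O)c2cc3cnc(Nc4ccc5[nH]ccc5c4)nc3n(C)c2=O)cc1`) differs from compound 1 by having (4-methoxyphenyl)sulfonyl in place of (2,4-difluorophenyl)carbamoyl on an aromatic carbon. Going by the values given here, the expectation rests on only two sulfonyl examples, compound 2 at 1000 nM and compound 3 at 1000 nM in this assay and is therefore tentative. A lower number is expected, with a 5.6-fold lower number from compound 1 to compound 4 (0.74 log units; beyond the scatter) as the estimated step, which would lie beyond the scatter. Compound 4 is expected near 900 nM and between 250 nM and 3000 nM.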

Compound 4, half-maximal inhibitory concentration: 500 nM
Compound 4: the middle estimate sits 1.8-fold (0.26 log units) above what was measured; the measured number falls inside the stated range.
By their numbers in this assay, from the lowest: compounds 4, 2 and 3 (each within the scatter of the next); then compound 1.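

In this assay, for the compounds shown here, the step at this aromatic carbon is a 10-fold lower number from compound 1 to compound 4 (1.00 log units; beyond the scatter), the first change at this position measured on its own with the rest of the molecule held constant. It shows that this one place can move the number beyond the scatter, and that a (4-methoxyphenyl)sulfonyl group is tolerated here at least as well as the (2,4-difluorophenyl)carbamoyl group. No measurement here explains the difference.

The swap alters the linking unit and the ring's substituents together, so the step cannot be divided between sulfonyl for carbamoyl and methoxy for the two fluorines; a (4-methoxyphenyl)carbamoyl group on the same core would help separate the two. On these data alone, how a much smaller group, such as an amine or a carboxylic acid, would behave at this carbon also remains open.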